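Replacing a Methyl with Methylsulfanyl on the Oxazole Core

The source may report more compounds than this note shows. Statements on the series, on what has been measured and on what is new or still open speak of the compounds shown alone.

Measured so far in an assay on HEK-293T cells for inhibition of diacylglycerol lipase-alpha (Homo sapiens), read by colorimetric assay; on this read-out lower numbers stand for stronger inhibition and higher numbers for weaker inhibition:
compound 1 `O=C(CCCCCCc1ccccc1)c1nc(C(=O)C(F)(F)F)co1` gives 123 nM;
compound 2 `CS(=O)(=O)c1coc(C(=O)CCCCCCc2ccccc2)n1` gives 389 nM;
compound 3 `Cc1coc(C(=O)CCCCCCc2ccccc2)n1` gives > 10000 nM.

The value for compound 3 is a limit of this assay, not a measured number. Compound 3 therefore stands at the weak end of the three, as the limit of > 10000 nM in this assay, at which 1 of the 3 values shown sits, shows. Compound 4 `CSc1coc(C(=O)CCCCCCc2ccccc2)n1` differs from it by one change: methylsulfanyl in place of methyl on an aromatic carbon.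

Among the compounds with values here, two measured steps bear on this place on the ring. The step of an at least 25-fold higher number from compound 2 to compound 3 (1.41 log units; beyond the scatter) and the step of an at least 81-fold higher number from compound 1 to compound 3 (1.91 log units; beyond the scatter) both show that the methyl group leaves compound 3 far weaker than either larger substituent. Methylsulfanyl is a new group here, so its effect is unknown; a gain is plausible but uncertain. Compound 4 is estimated at 8000 nM, within 2000 nM to 30000 nM, meaning an expected step of an at least 1.2-fold lower number from compound 3 to compound 4 (0.09 log units; that floor lies within the scatter).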

Compound 4, half-maximal inhibitory concentration: > 10000 nM
Compound 4 was reported as a limit; the forecaster's own chance of this, stated with the estimate: 55%; at least 1.2-fold (0.09 log units) between middle value and limit.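

In this assay compound 4, like compound 3, is reported only as a limit: the limit of > 10000 nM in this assay, at which 2 of the 4 values shown sit.

The step between these two compounds cannot be read, as neither value is an exact number. Methylsulfanyl in place of methylsulfonyl gives an at least 25-fold higher number from compound 2 to compound 4 (1.41 log units; beyond the scatter), and methylsulfanyl in place of (trifluoromethyl)carbonyl gives an at least 81-fold higher number from compound 1 to compound 4 (1.91 log units; beyond the scatter), so having a sulfur atom at this place is not enough to match the inhibition of compound 2.

The compounds shown leave open whether a nitrile, a methyl ester or a primary amide here would come close to compound 1 or compound 2. They also leave open how weak compound 3 and compound 4 really are.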